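A few compounds are considered here, and "the series" means these few. Any claim that something is new, unique, unknown or untested is made for them only; others in the source may bear on it.

Compound 1 `Cc1cc(-c2nc3sc(C)cn3c2/C=N/NC(=N)N)c(C)s1`: 4790 nM
Compound 2 `Cc1cn2c(/C=N/NC(=N)N)c(-c3ccsc3)nc2s1`: 7590 nM
Compound 3 `N=C(N)N/N=C/c1c(-c2cccs2)nc2sccn12`: 12300 nM

In a functional assay on cells (Cancer cell lines, Homo sapiens) for inhibition (on this read-out lower numbers stand for stronger inhibition of growth and higher numbers for weaker inhibition of growth), compound 3 has the highest of the three numbers. Its gap to compound 2 lies within the scatter, and its gap to compound 1 lies beyond it. Compound 4 `Cc1cn2c(/C=N/NC(=N)N)c(-c3cccs3)nc2s1` differs from compound 3 by methyl in place of hydrogen on an aromatic carbon. For the measured compounds named here, compound 1 and compound 2 both carry this methyl, but no measured pair isolates it. Going by the values given here, the only measured step, a 1.6-fold higher number from compound 1 to compound 2 (0.20 log units; within the scatter), is a change elsewhere and stays within the scatter. The expected change is a 1.3-fold lower number from compound 3 to compound 4 (0.11 log units; within the scatter), with no shift beyond the scatter anticipated. For compound 4 the estimated value is 9500 nM, with an expected range of 4500 nM to 20000 nM.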

Compound 4, concentration for 50% growth inhibition: 3020 nM
Estimate against measurement, compound 4: 3.1-fold (0.50 log units) above; measured number below the stated range.
By their numbers in this assay, from the lowest: compounds 4, 1, 2 and 3 (each within the scatter of the next, the first and the last beyond it).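

Methyl in place of hydrogen next to the ring sulfur gives a 4.1-fold lower number from compound 3 to compound 4 (0.61 log units; beyond the scatter) as the first isolated read of this position, and the step lies beyond the scatter. With this methyl kept, thiophen-2-yl in place of thiophen-3-yl gives a 2.5-fold lower number from compound 2 to compound 4 (0.40 log units; beyond the scatter) as a further step beyond the scatter, while thiophen-2-yl in place of 2,5-dimethylthiophen-3-yl gives a 1.6-fold lower number from compound 1 to compound 4 (0.20 log units; within the scatter) and stays within it. No supporting data bear on the cause of these steps.

On these data alone, whether an ethyl, a chlorine or an amine on this ring carbon would match methyl stays open. Also open, as far as these compounds go, is whether the methyl step carries over to the thiophen-3-yl compounds.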